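The source may report more compounds than this note shows. Statements on the series, on what has been measured and on what is new or still open speak of the compounds shown alone.

Compound 1 `CSCC[C@H](NC(=O)c1ccc(NCc2cncn2Cc2ccccc2C#N)cc1-c1ccccc1)C(=O)O` gives in a functional assay on NIH3T3 cells (Mus musculus) (a lower number here means that less compound is needed, a higher number that more compound is needed for the effect), only the limit > 10 uM.
Compound 2 `N#Cc1ccc(Cn2cncc2CNc2ccc(C(=O)Nc3cccc([N+](=O)[O-])c3)c(-c3ccccc3)c2)cc1` gives in this assay only the limit > 10 uM.
Compound 3 `CC(C)NC(=O)c1ccc(NCc2cncn2Cc2ccc(C#N)cc2)cc1-c1ccccc1` gives in this assay only the limit > 10 uM.

None of the three measured compounds has a number in this assay; every value is a limit, and compound 1 stands at that limit like the other two (the limit of > 10 uM in this assay, at which 3 of the 3 values shown sit). For the measured compounds named here, the only single-point step among them, a step that the two limits leave unreadable from compound 2 to compound 3, runs between two limits and therefore says nothing about its size.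

Compound 4 `CSCC[C@H](NC(=O)c1ccc(NCc2cncn2Cc2cccc(C)c2)cc1-c1ccccc1)C(=O)O` differs from compound 1 in one place: 3-methylphenyl in place of 2-cyanophenyl on a saturated chain carbon bound to an aromatic nitrogen. Going by the values given here, no measured step touches this part of the molecule, so no measured step bears on it. What the data do show is that three variations of the shared core, at the amide side and at the benzyl side, all stay at the limit (the limit of > 10 uM in this assay, at which 3 of the 3 values shown sit).

Compound 4 is therefore expected to stay at the limit as well, with a step that the limit leaves unreadable from compound 1 to compound 4 expected to be no step beyond the scatter. The estimate for compound 4 in this assay is 20 uM, ranging from 5 uM to 100 uM.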

Compound 4, concentration for half-maximal effect: > 10 uM
Compound 4 gave a limit, no number (the forecaster's own chance of this, stated with the estimate: 85%); the middle value does not contradict the limit.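

In this assay compound 4 gives > 10 uM, which is a limit and not a number, and no step can be read between compound 1 and compound 4, since both sit at the same limit: the limit of > 10 uM in this assay, at which 4 of the 4 values shown sit.

The compounds shown leave open how far each lies beyond that limit, and whether any change to the shared core would give a measurable value.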